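The source may report more compounds than this note shows. Statements on the series, on what has been measured and on what is new or still open speak of the compounds shown alone.

Three compounds with a shared core carry different amines at the end of a three-carbon chain. Compound 1 `CCN(CC)CCCOc1cc2ncnc(Nc3ccc(C#N)cc3)c2cc1OC` holds a diethylamino group there, compound 2 `COc1cc2c(Nc3ccc(C#N)cc3)ncnc2cc1OCCCN1CCCC1` a pyrrolidin-1-yl group, and compound 3 `COc1cc2c(Nc3ccc(C#N)cc3)ncnc2cc1OCCCN1CCCCC1CCO` a 2-(2-hydroxyethyl)piperidin-1-yl group. Among the measured compounds shown here, in a functional assay on SH-SY5Y cells (Homo sapiens) for antiproliferative activity, read by MTT assay, with a stated time of 72 h (a lower number here means a stronger inhibitor, a higher number a weaker inhibitor), compound 2 gives 8080 nM, the only plain number among the three. For compound 1 the value > 100000 nM is a limit of this assay, not a number. For compound 3 the value > 100000 nM is likewise a limit. Both limits sit at the limit of > 100000 nM in this assay, at which 2 of the 3 values shown sit. The change an at least 12-fold lower number from compound 1 to compound 2 (1.09 log units; beyond the scatter) therefore reads as a large gain, and the change an at least 12-fold higher number from compound 2 to compound 3 (1.09 log units; beyond the scatter) as a large loss, while the change a step that the two limits leave unreadable from compound 1 to compound 3 cannot be sized.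

Compound 4 `COc1cc2c(Nc3ccc(C#N)cc3)ncnc2cc1OCCCN1CCN(c2ccncc2)CC1` is not yet measured. Against compound 2 it shows (4-(pyridin-4-yl)piperazin-1-yl in place of pyrrolidin-1-yl on a saturated chain carbon, three bonds along the chain from an oxygen on an aromatic ring). The two readable steps both concern the same place and both point away from compound 2: the smaller diethylamino group and the larger hydroxyethyl-bearing ring each sit at the limit. Because compound 3 reached > 100000 nM with a larger ring, a higher number is expected for compound 4, a 5.0-fold higher number from compound 2 to compound 4 (0.69 log units; beyond the scatter). Compound 4 is therefore estimated at 40000 nM, within 8000 nM to 150000 nM, with a real chance that only a limit is reported.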

Compound 4, half-maximal inhibitory concentration: 31600 nM
Compound 4: the middle estimate sits 1.3-fold (0.10 log units) above what was measured; the range from low to high includes it.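

Replacing pyrrolidin-1-yl with the larger 4-(pyridin-4-yl)piperazin-1-yl at this place weakens the result in this assay, and the step is only modest: a 3.9-fold higher number from compound 2 to compound 4 (0.59 log units; beyond the scatter), so compound 2 keeps the lowest number of the four. A larger amine at the end of the chain therefore does not always push the value to the limit, as compound 4, with a second, aromatic ring on its amine, still gives a readable number, with an at least 3.1-fold lower number from compound 3 to compound 4 (0.50 log units; beyond the scatter) and an at least 3.1-fold lower number from compound 1 to compound 4 (0.50 log units; beyond the scatter). The values of compound 1 and compound 3 are limits and not numbers, so these two steps give only a minimum size and the step between those two compounds cannot be read: the limit of > 100000 nM in this assay, at which 2 of the 4 values shown sit.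

From the compounds shown here alone, it remains open which part of the new group carries the difference, the piperazine ring or the pyridine ring on it, and a 4-phenylpiperazin-1-yl or a morpholin-4-yl group at the same place would help separate the two. Also open, going by these compounds, is how a longer chain, such as four carbons, would change the value with these same amines.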